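The compounds below may be only part of what the source reports. "The series", "measured", "known", "first", "only" and "open" are said of these compounds alone.

Working notes on the series, all read in a functional assay on HL-60 cells (Homo sapiens) for inhibition, read by MTT assay, with a stated time of 48 h, tested at 10 uM; a higher number here means more inhibition of growth at the concentration tested, a lower number less inhibition of growth. Compound 1 (`Cc1cc(=O)c2c(O)cc(OCc3ccccc3)c([C@H]3CCN(C)C[C@H]3O)c2o1`) gives 24% and compound 2 (`Cc1cc(=O)c2c(O)c(CN3CCCCC3)c(O)c([C@H]3CCN(C)C[C@H]3O)c2o1`) gives 32% in this read-out. Compound 3 (`Cc1oc2c([C@H]3CCN(C)C[C@H]3O)c(O)cc(O)c2c(=O)c1C(O)c1ccccc1Br`) gives 52% and is the highest of the three, with both gaps beyond the usual scatter.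

The next compound is compound 4 (`COc1ccc(C(O)c2c(C)oc3c([C@H]4CCN(C)C[C@H]4O)c(O)cc(O)c3c2=O)cc1Br`), which carries 3-bromo-4-methoxyphenyl in place of 2-bromophenyl on a saturated chain carbon bound to an aromatic carbon and an oxygen on a saturated carbon. The same difference reads as (2-bromophenyl)(hydroxy)methyl to (3-bromo-4-methoxyphenyl)(hydroxy)methyl.

Going by the values given here, no measured pair differs in one place only, so the size of this change has no direct precedent. With compound 3 at 52% as the top value of a small set, a modest fall is expected rather than a rise, and it may stay within the scatter. The estimated move is a number 9 percentage points lower from compound 3 to compound 4 (within the scatter) in this read-out. For compound 4 the expected value is 43%, with an estimated range from 24% to 62%.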

Compound 4, percent growth inhibition at one concentration: 23%
Compound 4: middle estimate off by 20 percentage points, on the high side; measured number outside the range, below it.
By their numbers in this assay, from the lowest: compounds 4, 1 and 2 (each within the scatter of the next); then compound 3.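

On the saturated chain carbon bound to an aromatic carbon and an oxygen on a saturated carbon, the read-out in this assay responds to the aryl group: 3-bromo-4-methoxyphenyl in place of 2-bromophenyl gives a number 29 percentage points lower from compound 3 to compound 4 (beyond the scatter). Going by these compounds alone, this is the first single-place step, and it shows that the high value of compound 3 is not shared by every bromine-bearing aryl group at this carbon. Nothing measured here accounts for the fall.

The compounds shown do not separate the methoxy group from the changed place of the bromine, as the two differ together between compound 3 and compound 4. Also open, on these data alone, is how an unsubstituted phenyl or a pyridyl ring would read at this carbon.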